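Two Limits and an Ether-Bearing Analogue

The source may hold more compounds than are shown below. What is called first, only, known or untested is meant among the compounds shown, and "the series" means these compounds.

Compound 1 `CC#C[C@@H](Cc1nnn[nH]1)c1ccc(OCc2ccc3scc(-c4ccccc4C(F)(F)F)c3c2)cc1` was tested in an ADME assay on microsomes from liver (Homo sapiens) for metabolic stability (a lower number here means that the compound disappears faster, a higher number that the compound lasts longer), where compound 1 returned < 0.0667 h, a limit of the assay rather than a number. Compound 2 `CC#C[C@@H](Cc1nnn[nH]1)c1ccc(OCc2cc(C)c3scc(-c4ccccc4C)c3c2)cc1` likewise gave < 0.0667 h in this assay, again a limit. For the measured compounds named here, compound 1 therefore stands at the limit of < 0.0667 h in this assay, at which 2 of the 2 values shown sit, with no measured step to set it against. Compound 3 `CC#C[C@@H](Cc1nnn[nH]1)c1ccc(OCc2ccc3scc(-c4cc(OCCOC)ccc4C)c3c2)cc1` differs from compound 1 by 5-(2-methoxyethoxy)-2-methylphenyl in place of 2-(trifluoromethyl)phenyl on an aromatic carbon. Nothing shown points to a step beyond the scatter in either direction. The step expected here, a step that the limit leaves unreadable from compound 1 to compound 3, is accordingly small. Compound 3 is estimated at 0.05 h, between 0.02 h and 0.15 h, most likely reported again only as a limit.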

Compound 3, half-life: 0.867 h
For compound 3 the middle estimate is 17-fold (1.24 log units) below the measured one; the whole stated range lies below it.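

In this assay, the group on this aromatic carbon, two ring bonds from the ring sulfur, proves able to move the half-life: 5-(2-methoxyethoxy)-2-methylphenyl in place of 2-(trifluoromethyl)phenyl gives an at least 12-fold higher number from compound 1 to compound 3 (1.11 log units; beyond the scatter). Compound 3 is the only compound shown with a value that is a number and not a limit, whereas the earlier compounds gave no readable step: the limit of < 0.0667 h in this assay, at which 2 of the 3 values shown sit.

The compounds shown do not separate the 2-methoxyethoxy chain from the methyl group, which enter together, and the true size of the step stays unknown. As far as these compounds go, whether a plain methoxy group or an amine at the end of the chain would give a similar half-life remains open.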